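The source may report more compounds than this note shows. Statements on the series, on what has been measured and on what is new or still open speak of the compounds shown alone.

Compound 1 `COc1ccc(C(=O)/C=C\Nc2ccc(-c3nc4cc(OC)c(OC)c(OC)c4s3)cc2C)cc1F` in a functional assay on MIA PaCa-2 cells (Homo sapiens) for antiproliferative activity, read by sulforhodamine B assay, with a stated time of 48 h; on this read-out lower numbers stand for stronger inhibition and higher numbers for weaker inhibition: 1800 nM
Compound 2 `COc1ccc(C(=O)/C=C\Nc2ccc(-c3nc4cc(OC)c(OC)c(OC)c4s3)cc2)cc1[N+](=O)[O-]` in this assay: 15900 nM

Of these two, compound 2 has the higher number, and its gap to compound 1 lies beyond the scatter, so compound 2 is the weaker inhibitor here. Compound 3 `COc1ccc(C(=O)/C=C\Nc2ccc(-c3nc4cc(OC)c(OC)c(OC)c4s3)cc2)cc1F` differs from compound 2 in one place: fluoro in place of nitro on an aromatic carbon. Put another way, the 4-methoxy-3-nitrophenyl group of compound 2 becomes the 3-fluoro-4-methoxyphenyl group of compound 3. Among the compounds with values here, no measured pair shows this change directly. Within the data shown here, the only guide is compound 1, which also carries the 3-fluoro-4-methoxyphenyl group and gives 1800 nM. A large step toward stronger inhibition, beyond the scatter, is therefore expected in this assay. The expected change is a 9.9-fold lower number from compound 2 to compound 3 (1.00 log units; beyond the scatter). The estimate for compound 3 is 1600 nM, with an expected range from 450 nM to 6000 nM.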

Compound 3, half-maximal inhibitory concentration: 19400 nM
Compound 3: middle estimate off by 12-fold (1.08 log units), on the low side; the measured number lies above the stated range.
By their numbers in this assay, from the lowest: compound 1; then compounds 2 and 3 (each within the scatter of the next).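

In this assay, fluoro in place of nitro on the aromatic carbon ortho to a methoxy group gives a 1.2-fold higher number from compound 2 to compound 3 (0.09 log units; within the scatter), so the two groups cannot be told apart at this position when no methyl group is present. Hydrogen in place of methyl gives an 11-fold higher number from compound 1 to compound 3 (1.03 log units; beyond the scatter), which ties the lower number of compound 1 to its methyl group and not to its fluoro group. Nothing available explains either result.

The compounds shown leave open whether the methyl group would have the same effect alongside nitro instead of fluoro, and whether an ethyl group or a chlorine atom could take its place. They also leave open whether an amine or a hydroxyl group at the fluoro position would read any differently from fluoro and nitro.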